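Aryl variation at the amidine carbon of the shared core

This account rests on a few compounds, and the source may have more. Where it says the series, first, only, none or still open, it means among the compounds named here.

Measured so far in an assay on LM cells for displacement of a labelled ligand from Neuropeptide Y receptor type 5 (Homo sapiens); on this read-out lower numbers stand for stronger inhibition and higher numbers for weaker inhibition:
compound 1 `Fc1ccc(C2(c3ccc(F)cc3)CNC(c3cccc(F)c3)=N2)cc1`, 10 nM
compound 2 `CC(=O)c1cccc(C2=NC(c3ccc(F)cc3)(c3ccc(F)cc3)CN2)c1`, 44 nM
compound 3 `Cc1cccc(C2=NC(c3ccc(F)cc3)(c3ccc(F)cc3)CN2)c1`, 30 nM

Compound 3 holds the second highest of the three numbers; its nearest neighbour is compound 2, a 1.5-fold lower number from compound 2 to compound 3 (0.17 log units; within the scatter), its furthest compound 1, a 3.0-fold higher number from compound 1 to compound 3 (0.48 log units; beyond the scatter). Compound 4 `Fc1ccc(C2(c3ccc(F)cc3)CNC(c3cccnc3)=N2)cc1` differs from compound 3 by pyridin-3-yl in place of 3-methylphenyl on a carbon with a double bond to nitrogen.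

The steps measured so far all alter the substituent on that aryl ring rather than the ring itself: a 4.4-fold higher number from compound 1 to compound 2 (0.64 log units; beyond the scatter) and a 3.0-fold higher number from compound 1 to compound 3 (0.48 log units; beyond the scatter), both modest, and a 1.5-fold lower number from compound 2 to compound 3 (0.17 log units; within the scatter), within the scatter. None replaces the ring by a heteroaryl, so the bearing on compound 4 is indirect. The step to compound 4 is therefore expected to be small, a 1.3-fold higher number from compound 3 to compound 4 (0.12 log units; within the scatter), in this assay. The estimate for compound 4 is 40 nM, range 12 nM to 130 nM.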

Compound 4, half-maximal inhibitory concentration: 7.2 nM
Compound 4: the middle estimate sits 5.6-fold (0.74 log units) above what was measured, outside the stated range (below it).
By their numbers in this assay, from the lowest: compounds 4 and 1 (each within the scatter of the next); then compounds 3 and 2 (each within the scatter of the next).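

Pyridin-3-yl shows that the aryl ring itself can change at this carbon, not only its substituent, without loss in this assay. The heteroaryl gives a 4.2-fold lower number from compound 3 to compound 4 (0.62 log units; beyond the scatter) and a 6.1-fold lower number from compound 2 to compound 4 (0.79 log units; beyond the scatter), whereas a 1.4-fold lower number from compound 1 to compound 4 (0.14 log units; within the scatter) stays within the scatter, so here pyridin-3-yl and 3-fluorophenyl cannot be separated. No measurement at hand accounts for these steps.

Going by these compounds, what a pyridin-4-yl ring, or an amine or carboxylic acid carried on the pyridine ring, would give at this carbon remains open.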